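Swapping the aryl group on the ring nitrogen: a small step

A few compounds are considered here, and "the series" means these few. Any claim that something is new, unique, unknown or untested is made for them only; others in the source may bear on it.

In a functional assay on Hep 3B2 cells (Homo sapiens) for inhibition, read by sulforhodamine B assay, with a stated time of 72 h, tested at 10 uM (a higher number here means more inhibition at the concentration tested (going by the name of the read-out), a lower number less inhibition), compound 2 `C[C@H](Nc1ncnc2[nH]cnc12)c1nn(-c2ccccn2)c2cc(F)ccc12` gives 12%, a number that sits among three that all fall within the scatter of one another. Compound 1 `C[C@H](Nc1ncnc2[nH]cnc12)c1nn(-c2cccc(S(C)(=O)=O)c2)c2cc(F)ccc12` gives 11% in this assay, and compound 3 `C[C@H](Nc1ncnc2[nH]cnc12)c1nn(-c2cccnc2)c2cc(Cl)ccc12` gives 13%; the two of them differ in more than one place, so their values are only to be read side by side. Compound 4 `C[C@H](Nc1ncnc2[nH]cnc12)c1nn(-c2cccc(F)c2)c2cc(F)ccc12` has not yet been measured in this assay. It differs from compound 2 as follows: 3-fluorophenyl in place of pyridin-2-yl on an aromatic nitrogen. Going by the values given here, the one measured step that bears on this position is a number 1 percentage points higher from compound 1 to compound 2 (within the scatter), which shows that exchanging the group on that aromatic nitrogen left the inhibition essentially where it was. With only this to go on, and the three numbers so close together, no step beyond the scatter is expected, in either direction. The step from compound 2 to compound 4 is therefore estimated as no change at the digits printed from compound 2 to compound 4 (within the scatter). Compound 4 is thus expected to give about 12% in this assay, with a likely range from 2% to 25%.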

Compound 4, a percentage reported as inhibition, at one concentration (the size of the read-out at that concentration, not a potency): 28%
The estimate for compound 4 lay 16 percentage points below the measured number; measured number above the stated range.
By their numbers in this assay, from the lowest: compounds 1, 2 and 3 (each within the scatter of the next); then compound 4.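

In this assay the group on the aromatic nitrogen proves able to move the number: 3-fluorophenyl in place of pyridin-2-yl gives a number 16 percentage points higher from compound 2 to compound 4 (beyond the scatter) and so goes further than the earlier exchange at this position, which gave a number 1 percentage points higher from compound 1 to compound 2 (within the scatter). Fluoro in place of methylsulfonyl on an aromatic carbon of the aryl group gives a number 17 percentage points higher from compound 1 to compound 4 (beyond the scatter) in the same assay, so among these three compounds, which share the fluoro-bearing core, 3-fluorophenyl alone stands apart from the other two groups. No measurement at hand bears on why this change raises the number.

On these data alone, it remains open whether the step belongs to the carbon-only ring or to its fluoro substituent, which a plain phenyl would help to separate. As far as these compounds go, how a 3-chlorophenyl or a 3-aminophenyl would compare also remains open.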